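The compounds below may be only part of what the source reports. "The series", "measured", "known", "first", "only" and "open" are said of these compounds alone.

Measured in an ADME assay on cells (Hepatocyte, Mus musculus) for cytotoxicity, read by MTT assay, with a stated time of 24 h; on this read-out higher numbers stand for lower toxicity in this test and lower numbers for higher toxicity in this test:

- compound 1 `Cc1ccc(-c2nn(-c3ccccc3)cc2-c2nc3ccccc3[nH]2)cc1`: > 300000 nM (a limit of the assay)
- compound 2 `Cc1ccc(-c2nn(-c3ccccc3)cc2-c2nc3ccccc3n2S(=O)(=O)c2ccccc2)cc1`: 189000 nM
- compound 3 `Cc1ccc(-c2nn(-c3ccccc3)cc2-c2nc3ccccc3n2S(=O)(=O)c2ccc(C)cc2)cc1`: 102000 nM

Compound 3 and compound 2 sit together on this read-out, with a 1.9-fold lower number from compound 2 to compound 3 (0.27 log units; within the scatter). Against the unsubstituted nitrogen of the first entry, the sulfonyl compounds show an at least 1.5-fold lower number from compound 1 to compound 2 (0.20 log units; that floor lies within the scatter) and an at least 2.9-fold lower number from compound 1 to compound 3 (0.46 log units; beyond the scatter). Both of these are floors rather than measured sizes, and they rest on (the limit of > 300000 nM in this assay, at which 1 of the 3 values shown sits).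

Compound 4 `Cc1ccc(-c2nn(-c3ccccc3)cc2-c2nc3ccccc3n2S(=O)(=O)c2cc(C)ccc2C)cc1` carries 2,5-dimethylphenyl in place of 4-methylphenyl on a sulfonyl sulfur. The sulfonyl link stays, so the two steps away from the limit do not apply directly to this change. The closest measured precedent is a 1.9-fold lower number from compound 2 to compound 3 (0.27 log units; within the scatter), where methyl takes the place of hydrogen on an aromatic carbon. Among the compounds with values here, that single step is the only guide to the size of the change on the aryl group, and it gives no firm direction.

No shift beyond the scatter is therefore expected in this assay. The expected change is a 1.1-fold lower number from compound 3 to compound 4 (0.05 log units; within the scatter). The estimate for compound 4 is 90000 nM. The expected range for compound 4 runs from 40000 nM to 200000 nM.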

Compound 4, half-maximal cytotoxic concentration: 231000 nM
The estimate for compound 4 lay 2.6-fold (0.41 log units) below the measured number, outside the stated range (above it).
By their numbers in this assay, from the lowest: compounds 3, 2 and 4 (each within the scatter of the next, the first and the last beyond it). At a limit, above all of these: compound 1.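

In this assay, the aryl group on the sulfonyl sulfur can shift the number beyond the scatter: a 2.3-fold higher number from compound 3 to compound 4 (0.36 log units; beyond the scatter), whereas the earlier change on this aryl group, a 1.9-fold lower number from compound 2 to compound 3 (0.27 log units; within the scatter), did not go beyond it. Within the data shown here, the phenyl and 2,5-dimethylphenyl compounds are not separated, with a 1.2-fold higher number from compound 2 to compound 4 (0.09 log units; within the scatter), so among the sulfonyl compounds only the pair with 4-methylphenyl and 2,5-dimethylphenyl stands clearly apart, and adding methyl groups to this aryl group does not give a steady trend across the three. Against the free nitrogen of compound 1, only a floor can be read, an at least 1.2-fold lower number from compound 1 to compound 4 (0.11 log units; that floor lies within the scatter), and it gives no true size for this step: the limit of > 300000 nM in this assay, at which 1 of the 4 values shown sits.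

Which of the two methyl groups in 2,5-dimethylphenyl goes with the higher number remains open, as does the true size of any step away from compound 1. Also open, going by these compounds, is how the number responds on this aryl group to a group other than methyl, such as a methoxy group, an amine or a carboxylic acid.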